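Chain extension with a piperidine end on compound 3

This account rests on a few compounds, and the source may have more. Where it says the series, first, only, none or still open, it means among the compounds named here.

Compound 3, `CCCCCN1CCC(NC(=O)c2cc(Cl)c(N)cc2OC)CC1`, is the reference point here. In a functional assay on HEK293 cells for agonist activity at 5-hydroxytryptamine receptor 4 (Homo sapiens), read by cAMP accumulation (a higher number here means that more compound is needed for the effect, a lower number that less compound is needed), compound 3 gives 25.1 nM, the lowest of the three numbers. Compound 1, `CC(C)n1c(=O)n(C(=O)NC2CCNCC2)c2ccccc21`, gives 316 nM, a gap beyond the usual scatter, and compound 2, `COc1ccc2[nH]cc(C(=O)NC3CCNCC3)c2c1`, gives 100000000 nM, far beyond it. The unmeasured compound 4, `COc1cc(N)c(Cl)cc1C(=O)NC1CCN(CCCCCCCCN2CCCCC2)CC1`, differs from compound 3 by 3-(piperidin-1-yl)propyl in place of hydrogen on a saturated chain carbon, five bonds along the chain from an amine nitrogen in a ring. Within the data shown here, no measured pair shows such a change, so only the three values and the nature of the addition guide the expectation. The writer expects a small step toward a higher number, within or just past the scatter, a 1.6-fold higher number from compound 3 to compound 4 (0.20 log units; within the scatter). For compound 4 the estimate in this assay is 40 nM, with a range from 8 nM to 200 nM.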

Compound 4, half-maximal effective concentration: 3.16 nM
Compound 4: the middle estimate sits 13-fold (1.10 log units) above what was measured, outside the stated range (below it).
By their numbers in this assay, from the lowest: compound 4; then compound 3; then compound 1; then compound 2.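

In this assay the step is a 7.9-fold lower number from compound 3 to compound 4 (0.90 log units; beyond the scatter) and shows that this saturated chain carbon, five bonds along the chain from an amine nitrogen in a ring, accepts 3-(piperidin-1-yl)propyl in place of hydrogen and that the number falls with it. No measurement shown here explains the drop. As far as these compounds go, it remains open whether the piperidine ring or the added chain length carries the step: a plain longer chain of the same reach, or a morpholine or a carboxylic acid at its end, could separate the two.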